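Heteroaryl variation on the oxazole ketone series

The source may report more compounds than this note shows. Statements on the series, on what has been measured and on what is new or still open speak of the compounds shown alone.

Compound 1 `N#Cc1ccc(-c2cnc(C(=O)CCCCCCc3ccccc3)o2)cc1` gives 40 nM in an assay (Rattus norvegicus) for inhibition of Fatty-acid amide hydrolase 1 (Homo sapiens); a higher number here means a weaker inhibitor, a lower number a stronger inhibitor. Compound 2 `Cc1cccc(-c2cnc(C(=O)CCCCCCc3ccccc3)o2)n1` gives 3.3 nM. Compound 3 `NC(=O)c1ccc(-c2cnc(C(=O)CCCCCCc3ccccc3)o2)nc1` gives 1.2 nM.

Compound 3 stands lowest of the three numbers: the step is a 33-fold lower number from compound 1 to compound 3 (1.52 log units; beyond the scatter) and a 2.8-fold lower number from compound 2 to compound 3 (0.44 log units; beyond the scatter), both beyond the scatter. Compound 4 `O=C(CCCCCCc1ccccc1)c1ncc(-c2ncccn2)o1` differs from compound 3 by pyrimidin-2-yl in place of 5-carbamoylpyridin-2-yl on an aromatic carbon. Within the data shown here, the steps that bear on this change are the large one, a 33-fold lower number from compound 1 to compound 3 (1.52 log units; beyond the scatter), and the modest one, a 2.8-fold lower number from compound 2 to compound 3 (0.44 log units; beyond the scatter). Compound 4, like compound 2, carries a six-membered aromatic ring without the carbamoyl group at the same place; the gap between compound 2 and compound 3 was modest, so a modest rise in the inhibition constant is expected, close to the edge of the scatter. Compound 4 is therefore expected to show a 2.5-fold higher number from compound 3 to compound 4 (0.40 log units; beyond the scatter). Compound 4 is estimated at 3 nM in this assay, within a range from 0.8 nM to 12 nM.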

Compound 4, inhibition constant: 5.3 nM
Estimate against measurement, compound 4: 1.8-fold (0.25 log units) below; the measured number falls inside the stated range.
By their numbers in this assay, from the lowest: compound 3; then compounds 2 and 4 (each within the scatter of the next); then compound 1.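

In this assay, pyrimidin-2-yl on this aromatic carbon, next to the ring oxygen, does not match 5-carbamoylpyridin-2-yl (a 4.4-fold higher number from compound 3 to compound 4 (0.65 log units; beyond the scatter)), yet it keeps much of the gain over 4-cyanophenyl (a 7.5-fold lower number from compound 1 to compound 4 (0.88 log units; beyond the scatter)). Against 6-methylpyridin-2-yl the change stays within the scatter (a 1.6-fold higher number from compound 2 to compound 4 (0.21 log units; within the scatter)), so these two rings without a carbamoyl group cannot be told apart here. Compound 3, the only one of the four carrying a carbamoyl group, thus remains alone at the low end of the series.

From the compounds shown here alone, what a carboxylic acid or an amine in place of the carbamoyl group on the pyridin-2-yl ring would do stays open, as does the effect of a pyridin-2-yl ring with no substituent. Nothing given here accounts for these differences.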